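This account rests on a few compounds, and the source may have more. Where it says the series, first, only, none or still open, it means among the compounds named here.

Measured compounds:

Compound 1 `O=C(CN1CCCC1)N1CCC(NS(=O)(=O)c2cc(S(=O)(=O)c3ccccc3)ccc2C(F)(F)F)CC1`: in an assay on isolated protein for binding affinity to secreted frizzled-related protein 1 (Homo sapiens), read by fluorescence (a higher number here means a weaker inhibitor, a lower number a stronger inhibitor), compound 1 gives 110 nM
Compound 2 `O=C(CN1CCNCC1)N1CCC(NS(=O)(=O)c2cc(S(=O)(=O)c3ccccc3)ccc2C(F)(F)F)CC1`: compound 2 gives 140 nM
Compound 3 `CC(C)(C)C(=O)N1CCC[C@H]1C(=O)N1CCC(NS(=O)(=O)c2cc(S(=O)(=O)c3ccccc3)ccc2C(F)(F)F)CC1`: compound 3 gives 40 nM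

Compound 3 has the lowest number of the three, with a 2.8-fold lower number from compound 1 to compound 3 (0.44 log units; beyond the scatter) and a 3.5-fold lower number from compound 2 to compound 3 (0.54 log units; beyond the scatter) both beyond the scatter, while the step of a 1.3-fold higher number from compound 1 to compound 2 (0.10 log units; within the scatter) stays within it.

Compound 4 `CN(C)CC(=O)N1CCC[C@H]1C(=O)N1CCC(NS(=O)(=O)c2cc(S(=O)(=O)c3ccccc3)ccc2C(F)(F)F)CC1` differs from compound 3 in one place: (dimethylamino)methyl in place of tert-butyl on a carbonyl carbon. Going by the values given here, no measured step swaps one group for another on that carbonyl carbon, so none bears on it directly. The nearest guide is the step of a 1.3-fold higher number from compound 1 to compound 2 (0.10 log units; within the scatter), where exchanging one amine-bearing group for another at a different carbonyl changed little. Carrying that over, an amine-bearing group in place of the tert-butyl is expected to leave the number close to that of compound 3, as a 1.4-fold higher number from compound 3 to compound 4 (0.14 log units; within the scatter), with no step beyond the scatter expected in either direction.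

Compound 4 is therefore estimated at 55 nM in this assay, within a range of 20 nM to 160 nM.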

Compound 4, half-maximal inhibitory concentration: 90 nM
The estimate for compound 4 lay 1.6-fold (0.21 log units) below the measured number, and the stated range covers the measured number.
By their numbers in this assay, from the lowest: compound 3; then compounds 4, 1 and 2 (each within the scatter of the next).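

Going by these compounds alone, this is the first swap measured on this carbonyl carbon, and in this assay it shows that the position responds to the group it carries: (dimethylamino)methyl in place of tert-butyl gives a 2.3-fold higher number from compound 3 to compound 4 (0.35 log units; beyond the scatter), although both groups hold 4 heavy atoms. The 1-acylated pyrrolidin-2-yl unit alone does not keep compound 4 apart from the simpler amides, with a 1.2-fold lower number from compound 1 to compound 4 (0.09 log units; within the scatter) and a 1.6-fold lower number from compound 2 to compound 4 (0.19 log units; within the scatter) both within the scatter, so the edge that compound 3 holds over compound 1 and compound 2 depends on what sits on this carbonyl carbon. No measurement here gives a reason for the change at this position.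

One swap cannot separate losing the tert-butyl from gaining the amine nitrogen. An isopropyl, a cyclohexyl or a carboxylic acid on this carbonyl carbon would help tell these apart.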